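Three sulfonamides at the assay limit, and a dichloro analogue

This account rests on a few compounds, and the source may have more. Where it says the series, first, only, none or still open, it means among the compounds named here.

Compound 1, `O=S(=O)(Nc1ccc(-c2nc3ccccc3o2)cc1)c1cccc(F)c1`, in an assay on isolated protein for inhibition of malate dehydrogenase, mitochondrial (Sus scrofa), with stated times of 45 min and 30 min (a higher number here means a weaker inhibitor, a lower number a stronger inhibitor), gives > 63000 nM, which is a limit of the assay and not a number.
Compound 2, `O=S(=O)(Nc1ccc(-c2nc3ccccc3o2)cc1)c1cccs1`, in this assay gives > 63000 nM, again a limit.
Compound 3, `C=Cc1ccc(S(=O)(=O)Nc2ccc(-c3nc4ccccc4o3)cc2)cc1`, in this assay gives > 63000 nM, also a limit.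

All three compounds share one core, and they differ only in the group on the sulfonyl sulfur. Compound 3 stands with the others at the limit of > 63000 nM in this assay, at which 3 of the 3 values shown sit, so no one of the three can be called stronger or weaker than another. The steps among them are unreadable for the same reason: a step that the two limits leave unreadable from compound 1 to compound 2, a step that the two limits leave unreadable from compound 1 to compound 3 and a step that the two limits leave unreadable from compound 2 to compound 3 each run between two limits.

The unmeasured compound 4, `O=S(=O)(Nc1ccc(-c2nc3ccccc3o2)cc1)c1ccc(Cl)c(Cl)c1`, changes the same place once more: 3,4-dichlorophenyl in place of 4-vinylphenyl on a sulfonyl sulfur.

Every measured step bears on this change in principle, since each swaps the group on the sulfonyl sulfur, but none of them has a readable size. What they do show is that three different groups at this position all left inhibition at the limit. The expectation for compound 4 is therefore that it behaves alike, with no readable step, as a step that the limit leaves unreadable from compound 3 to compound 4 expresses. Compound 4 is estimated at 80000 nM, expected to fall between 40000 nM and 200000 nM, most likely reported only as a limit.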

Compound 4, half-maximal inhibitory concentration: > 63000 nM
Compound 4 was reported as a limit; the forecaster's own chance of this, stated with the estimate: 85%; the middle value does not contradict the limit.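

Compound 4 also sits at a limit of the assay and not at a number, so no step from compound 1, compound 2 or compound 3 to compound 4 can be read: the limit of > 63000 nM in this assay, at which 4 of the 4 values shown sit.

The compounds shown leave open whether any group on the sulfonyl sulfur of the shared core would give a readable value in this assay.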